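This account rests on a few compounds, and the source may have more. Where it says the series, first, only, none or still open, it means among the compounds named here.

For the measured compounds named here, compound 2 `O=c1ccoc2cc(OCc3cn(Cc4ccc(Cl)cc4Cl)nn3)ccc12` is one of two compounds measured in an ADME assay on L02 cells (Homo sapiens) for cytotoxicity, read by MTT assay, with a stated time of 48 h; on this read-out lower numbers stand for stronger inhibition and higher numbers for weaker inhibition. In this assay compound 2 gives only a limit, > 300000 nM. Compound 1 `O=c1ccoc2cc(OCc3cn(Cc4cccc(Br)c4)nn3)ccc12` likewise gives only a limit in this assay, > 300000 nM. Going by the values given here, the one recorded step, a step that the two limits leave unreadable from compound 1 to compound 2, cannot be sized because both of its ends sit at the limit of > 300000 nM in this assay, at which 2 of the 2 values shown sit. Compound 3 `O=c1ccoc2cc(OCc3cn(Cc4cccc(Cl)c4)nn3)ccc12` has not yet been measured in this assay; it differs from compound 2 by 3-chlorophenyl in place of 2,4-dichlorophenyl on a saturated chain carbon bound to an aromatic nitrogen. No measured step can be read for this kind of change, and both measured compounds rest at the limit, so no step beyond the scatter is expected in this assay in either direction. For compound 3 the value in this assay is therefore expected to be 300000 nM, within a range from 150000 nM to 600000 nM, most likely reported again only as a limit. The expected step is a number no higher from compound 2 to compound 3 (the limit leaves the size open).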

Compound 3, half-maximal inhibitory concentration: > 300000 nM
Compound 3: no number, only a limit (the forecaster's own chance of this, stated with the estimate: 85%); the middle value lies on the limit itself.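

No new step can be read among compound 1, compound 2 and compound 3 in this assay, because each gives only a limit and not a number: the limit of > 300000 nM in this assay, at which 3 of the 3 values shown sit. The compounds shown leave open whether these changes of the halogen-bearing ring alter the read-out at all.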